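Shrinking the Outer Ring to a Methoxy Group

This account rests on a few compounds, and the source may have more. Where it says the series, first, only, none or still open, it means among the compounds named here.

Compound 1, `CCc1ccc(-c2ccc(NC3=CC(=O)c4ncncc4C3=O)cc2)cc1`, gives 3100 nM.
Compound 2, `O=C1C(Nc2ccc(Oc3ccccc3)cc2)=CC(=O)c2ncncc21`, gives 3600 nM.
Compound 3, `O=C1C(Nc2ccc(-c3ccc(F)cc3)cc2)=CC(=O)c2ncncc21`, gives 4400 nM.

In a functional assay on BXPC-3 cells (Homo sapiens) for cytotoxicity, read by MTT assay, with a stated time of 72 h (on this read-out lower numbers stand for stronger inhibition and higher numbers for weaker inhibition), the three measured compounds sit close together. Compound 3 shows the highest number of the three, yet its steps from the others, a 1.4-fold higher number from compound 1 to compound 3 (0.15 log units; within the scatter) and a 1.2-fold higher number from compound 2 to compound 3 (0.09 log units; within the scatter), both lie within the scatter, as does a 1.2-fold higher number from compound 1 to compound 2 (0.06 log units; within the scatter). All three carry a ring-bearing group at the same place on the shared core, and swapping one such group for another has moved nothing beyond noise.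

Compound 4, `COc1ccc(NC2=CC(=O)c3ncncc3C2=O)cc1`, takes a different route: methoxy in place of 4-fluorophenyl on an aromatic carbon. The two steps that touch this place, from compound 1 and compound 2 to compound 3, only exchanged one large group for another; none removed the outer ring altogether. The measured data therefore give no direct guide to so large a cut, and the estimate must be wide. A somewhat higher number than compound 3 is expected, a 1.6-fold higher number from compound 3 to compound 4 (0.20 log units; within the scatter), since every measured compound keeps a larger group there. Compound 4 is estimated at 7000 nM, with a range from 2000 nM to 25000 nM.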

Compound 4, half-maximal inhibitory concentration: 1700 nM
Estimate against measurement, compound 4: 4.1-fold (0.61 log units) above; the measured number lies below the stated range.
By their numbers in this assay, from the lowest: compounds 4, 1, 2 and 3 (each within the scatter of the next, the first and the last beyond it).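

Cutting the outer ring down to a methoxy group does not weaken the compound in this assay: the data show a 2.6-fold lower number from compound 3 to compound 4 (0.41 log units; beyond the scatter) and a 2.1-fold lower number from compound 2 to compound 4 (0.33 log units; beyond the scatter), while a 1.8-fold lower number from compound 1 to compound 4 (0.26 log units; within the scatter). The outer ring carried by the three earlier compounds is therefore not needed at this place for cytotoxicity in these cells, which exchanges of one large group for another could not reveal. No measurement shown here explains the shift.

The compounds shown leave open how small or how long the group at this place can be, for example a lone fluorine, a hydroxyl or a longer ethoxy chain. They also leave open whether an amine at this place would give numbers like those of the methoxy group.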